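Dropping the Methoxy Group from Compound 1

A few compounds are considered here, and "the series" means these few. Any claim that something is new, unique, unknown or untested is made for them only; others in the source may bear on it.

For the measured compounds named here, in an ADME assay on BEAS-2B cells (Homo sapiens) for cytotoxicity, read by MTT assay, with a stated time of 72 h (on this read-out lower numbers stand for stronger inhibition of growth and higher numbers for weaker inhibition of growth), compound 1 `COc1ccc(CNc2nc(SC)nc3ncccc23)cc1` gives 58500 nM, the highest of the three numbers measured so far. Compound 2 `CSc1nc(NCc2ccccc2)c2ccccc2n1` gives 38900 nM, a number within the scatter of compound 1. Compound 3 `Nc1nc([SeH])nc2ccccc12` gives 80 nM, far lower than compound 1 and beyond the scatter. Compound 4 `CSc1nc(NCc2ccccc2)c2cccnc2n1` has not yet been measured in this assay. It differs from compound 1 in one place: hydrogen in place of methoxy on an aromatic carbon. Going by the values given here, no measured pair shows this change by itself, so its size is unknown. Compound 2, which carries no methoxy, gives a number within the scatter of compound 1. The step of a 1.2-fold lower number from compound 1 to compound 4 (0.07 log units; within the scatter) is therefore expected to be none beyond the scatter. Compound 4 is expected to give about 50000 nM, between 20000 nM and 120000 nM.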

Compound 4, concentration for 50% growth inhibition: 25900 nM
Beside the measured number, compound 4's estimate is 1.9-fold (0.29 log units) above it; the range from low to high includes it.
By their numbers in this assay, from the lowest: compound 3; then compounds 4, 2 and 1 (each within the scatter of the next, the first and the last beyond it).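

In this assay, for the compounds shown here, the change can now be read directly for the first time: hydrogen in place of methoxy on an aromatic carbon, para to a large group, gives a 2.3-fold lower number from compound 1 to compound 4 (0.35 log units; beyond the scatter). The methoxy group at this position therefore has a modest effect on the number, one that lies beyond the scatter. Nothing available explains this step. From the compounds shown here alone, it remains open whether an amine, a fluorine atom or a longer ether chain at this place would move the number further. Going by these compounds, it is also open whether the same change would give a similar step on another core.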